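This account rests on a few compounds, and the source may have more. Where it says the series, first, only, none or still open, it means among the compounds named here.

Within the data shown here, in a functional assay on A549 cells (Homo sapiens) for cytotoxicity (on this read-out higher numbers stand for weaker inhibition and lower numbers for stronger inhibition), compound 2 `O=C1NC(c2ccccc2)CN1S(=O)(=O)c1ccccc1` gives 145000 nM, the only true number available so far. Compound 1 `Cc1ccc(S(=O)(=O)N2CC(c3ccc(Br)cc3)NC2=O)cc1` gives > 253000 nM, which is a limit of the assay. Compound 3 `Cc1ccc(S(=O)(=O)N2CC(c3ccccc3)NC2=O)cc1` carries methyl in place of hydrogen on an aromatic carbon, para to a large group, and so departs from compound 2 by methyl in place of hydrogen on an aromatic carbon. Among the measured compounds shown here, no measured step shows the effect of this change. Only a small move towards weaker inhibition is therefore expected in this assay, with a 1.2-fold higher number from compound 2 to compound 3 (0.07 log units; within the scatter) as the estimated size, hardly beyond the scatter. For compound 3 the expected value is 170000 nM, with an estimated range of 90000 nM to 320000 nM.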

Compound 3, half-maximal inhibitory concentration: 12500 nM
Estimate against measurement, compound 3: 14-fold (1.13 log units) above; the whole stated range lies above it.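

In this assay, the change from phenyl to 4-methylphenyl gives a 12-fold lower number from compound 2 to compound 3 (1.06 log units; beyond the scatter), so a single methyl at this place, para to a large group, moves the number well beyond the scatter. Removing the bromo while keeping that methyl gives an at least 20-fold lower number from compound 1 to compound 3 (1.30 log units; beyond the scatter), so this one-place change also matters. Compound 1 stands at a limit of the assay, so this second step gives only a minimum size: the limit of > 253000 nM in this assay, at which 1 of the 3 values shown sits.

The compounds shown leave open whether an ethyl, a methoxy or an amine at the methyl's place would give a similar number. They also leave open how bromo acts without the methyl.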